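The source may report more compounds than this note shows. Statements on the series, on what has been measured and on what is new or still open speak of the compounds shown alone.

Measured so far:
compound 1, `CCCCCCNc1ccc([N+](=O)[O-])cc1S(N)(=O)=O`: 3.8%
compound 2, `CC(C)(C)CCNc1ccc([N+](=O)[O-])cc1S(N)(=O)=O`: 14.5%

In an assay on HEK293 cells for inhibition of solute carrier family 12 member 2 (Homo sapiens), read by fluorescence, with a stated time of 30 min, tested at 100 uM (a lower number here means a weaker effect, a higher number a stronger effect of the compound at the concentration tested), compound 1 stands lowest of the two numbers; the nearest is compound 2, reached by a number 10.7 percentage points higher from compound 1 to compound 2 (beyond the scatter). Compound 3, `CCCCCCNc1ccc(C(=O)O)cc1S(N)(=O)=O`, differs from compound 1 as follows: carboxy in place of nitro on an aromatic carbon. Among the compounds with values here, no measured step bears on this change; the only step measured is a number 10.7 percentage points higher from compound 1 to compound 2 (beyond the scatter) and it concerns the chain, not the group on the aromatic carbon. The expectation for compound 3 is therefore anchored on compound 1, with a wide range, as a number 8.2 percentage points higher from compound 1 to compound 3 (within the scatter). Compound 3 is estimated at 12%, between 0% and 35%.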

Compound 3, a percentage reported as inhibition, at one concentration (the size of the read-out at that concentration, not a potency): 4.9%
Compound 3: the middle estimate sits 7.1 percentage points above what was measured, and the stated range covers the measured number.
By their numbers in this assay, from the lowest: compounds 1, 3 and 2 (each within the scatter of the next, the first and the last beyond it).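

In this assay, carboxy in place of nitro on this aromatic carbon, meta to the sulfamoyl group, gives a number 1.1 percentage points higher from compound 1 to compound 3 (within the scatter). Within the data shown here, this is the first reading at this position, and with the chain of compound 1 held constant, the exchange does not separate the two compounds. No supporting measurement bears on this result.

The compounds shown leave open what an amine, an amide or a methoxy group gives on this carbon. They also leave open whether carboxy gives the same result alongside the chain of compound 2.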